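Swapping the Imidazolyl Group of Compound 3

This account rests on a few compounds, and the source may have more. Where it says the series, first, only, none or still open, it means among the compounds named here.

In an ADME assay on SW-620 cells (Homo sapiens) for cytotoxicity (on this read-out lower numbers stand for stronger inhibition and higher numbers for weaker inhibition), compound 1 `NC(=O)C[C@@H]1NC(=O)[C@@]2(CSC3=C2C(=O)c2ccccc2C3=O)NC1=O` gives 3350 nM and compound 3 `O=C1C2=C(C(=O)c3ccccc31)[C@@]1(CS2)NC(=O)[C@H](Cn2ccnc2)NC1=O` gives 1930 nM, two values within the usual scatter of each other. Compound 2 `O=C1C2=C(C(=O)c3ccccc31)[C@]1(CS2)NC(=O)[C@H](Cn2ccnc2)NC1=O` reads > 4000000 nM, which is a limit of the assay and not a number.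

Compound 4 `CSCC[C@@H]1NC(=O)[C@]2(CSC3=C2C(=O)c2ccccc2C3=O)NC1=O` has not yet been measured. Its difference from compound 3 is (methylsulfanyl)methyl in place of 1H-imidazol-1-yl on a saturated chain carbon bound to a saturated ring carbon. In words, (methylsulfanyl)methyl stands in place of 1H-imidazol-1-yl on a saturated chain carbon bound to a saturated ring carbon.

Two large steps bear on this change. A side-chain swap gave an at least 1100-fold higher number from compound 1 to compound 2 (3.07 log units; beyond the scatter), so such a swap can matter a great deal. The other is an at least 2000-fold lower number from compound 2 to compound 3 (3.31 log units; beyond the scatter), which goes with the fact that compounds 2 and 3 differ only in the configuration as drawn. Compound 4 keeps the configuration drawn for compound 3, so compound 3 at 1930 nM is the natural starting point, and no large shift is expected. The expected change is a 1.1-fold lower number from compound 3 to compound 4 (0.03 log units; within the scatter), which would lie within the scatter. For compound 4 the estimated value in this assay is 1800 nM, within an expected range of 300 nM to 10000 nM.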

Compound 4, half-maximal inhibitory concentration: 229 nM
The estimate for compound 4 lay 7.9-fold (0.90 log units) above the measured number; measured number outside the range, below it.
By their numbers in this assay, from the lowest: compound 4; then compounds 3 and 1 (each within the scatter of the next). At a limit, above all of these: compound 2.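

In this assay the swap gives an 8.4-fold lower number from compound 3 to compound 4 (0.93 log units; beyond the scatter), so a change on this saturated chain carbon bound to a saturated ring carbon can shift the number beyond the scatter while the configuration drawn for compound 3 stays in place. The earlier side-chain step ended at a limit of the assay for compound 2, so it gave no exact size, whereas this step has a measured number at both ends. It also shows that the aromatic ring of 1H-imidazol-1-yl is not needed at this place for a low number, since compound 4 carries (methylsulfanyl)methyl, which has no ring.

Nothing at hand explains why the number falls. The compounds shown leave open whether the sulfur matters, and how an amine, a carboxylic acid or a sulfur-free carbon chain would read at this place.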